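The compounds below may be only part of what the source reports. "The series", "measured", "known", "first", "only" and "open" are said of these compounds alone.

Of the compounds shown here, two have been tested in a toxicity assay on NIH3T3 cells (Mus musculus) for cytotoxicity, read by resazurin assay (a higher number here means that more compound is needed for the effect, a lower number that less compound is needed), so far, and neither has given a number. Compound 1 `COC(=O)c1ccc(NCc2cncn2Cc2ccc(N)cc2)cc1-c1ccccc1` gives > 10000 nM in this assay, which is a limit of the measurement rather than a value. Compound 2 `O=C(c1ccc(NCc2cncn2Cc2ccc(-c3ccccc3)cc2)cc1-c1ccccc1)N1CCCCC1` gives > 1000 nM in this assay, again a limit only. Among the compounds with values here, compound 2 therefore stands at the limit of > 1000 nM in this assay, at which 1 of the 2 values shown sits, while the other known entry sits at the limit of > 10000 nM in this assay, at which 1 of the 2 values shown sits; no ordering of the two follows from limits, and no step between them can be stated.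

Compound 3 `CC(C)OC(=O)c1ccc(NCc2cncn2Cc2ccc(-c3ccccc3)cc2)cc1-c1ccccc1` is the next entry, differing from compound 2 in one place: isopropoxy in place of piperidin-1-yl on a carbonyl carbon.

Within the data shown here, with no measured step to rest on, the expectation for this assay is that the change from piperidin-1-yl to isopropoxy on the carbonyl carbon moves the read-out by no more than the scatter, with compound 3 most likely to return a limit as well. The step from compound 2 to compound 3 is thus estimated as a step that the limit leaves unreadable from compound 2 to compound 3. For compound 3 the estimated half-maximal effective concentration is 15000 nM, within a range of 3000 nM to 60000 nM.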

Compound 3, half-maximal effective concentration: > 10000 nM
Compound 3: no number, only a limit (the forecaster's own chance of this, stated with the estimate: 75%); the middle value does not contradict the limit.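

Within the data shown here, compound 2 and compound 3 both return only limits, not numbers, in this assay, and no step between them can be read. The compounds shown leave open the concentration at which any of them reaches the half-maximal effect, and whether isopropoxy and piperidin-1-yl on a carbonyl carbon differ at all in this read-out.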